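Positional swap of carboxy and methoxy on compound 3

The compounds below may be only part of what the source reports. "The series", "measured", "known", "first", "only" and "open" are said of these compounds alone.

Measured compounds:
compound 1 `Cn1sc2cc(OCc3cccc(-c4ccc(Cl)c(C(=O)O)c4)c3)ccc2c1=O`: 74.7%
compound 2 `O=C(O)c1cc(-c2cccc(COc3ccc4c(=O)n(CC5CC5)sc4c3)c2)ccc1Cl`: 38.4%
compound 3 `COc1ccc(C(=O)O)cc1-c1cccc(COc2ccc3c(c2)CN(C2CCCC2)C3=O)c1`: 79.2%

Going by the values given here, in an assay on HEK293 cells for positive allosteric modulation of metabotropic glutamate receptor 2 (Rattus norvegicus), read by thallium flux (a higher number here means a larger maximal response, a lower number a smaller maximal response), compound 3 gives the highest of the three numbers, though compound 1 sits within the scatter of it; compound 2 lies well beyond, and the one measured step, a number 36.3 percentage points lower from compound 1 to compound 2 (beyond the scatter), concerns a change on the saturated chain carbon of the core, not the biaryl end.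

Compound 4 `COc1ccc(-c2cccc(COc3ccc4c(c3)CN(C3CCCC3)C4=O)c2)cc1C(=O)O` differs from compound 3 only at that biaryl end: 3-carboxy-4-methoxyphenyl in place of 5-carboxy-2-methoxyphenyl on an aromatic carbon. Among the compounds with values here, no measured pair bears on this swap, so nothing beyond the scatter is expected; the estimated step is a number 7.2 percentage points lower from compound 3 to compound 4 (within the scatter). For compound 4 the expected value is 72%, within 48% to 92%.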

Compound 4, largest response reached (reported as percent of maximum), in percent of the reference or control that the assay uses: 78%
Compound 4: the middle estimate sits 6 percentage points below what was measured; low and high end bracket the measured number.
By their numbers in this assay, from the lowest: compound 2; then compounds 1, 4 and 3 (each within the scatter of the next).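

In this assay, 3-carboxy-4-methoxyphenyl in place of 5-carboxy-2-methoxyphenyl on this aromatic carbon gives a number 1.2 percentage points lower from compound 3 to compound 4 (within the scatter) and so leaves the maximal response unchanged within the scatter. Going by these compounds alone, this is the first step read at the biaryl end, and it shows that this arrangement of the same atoms can be exchanged here without a measurable loss. No available evidence bears on why the response holds.

On these data alone, whether this holds on the core of compound 1 stays open. So does the response with ethoxy in place of methoxy, or a tetrazole in place of the carboxylic acid.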